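Cytotoxicity notes: 4-fluorophenyl to 4-methoxyphenyl

The source may hold more compounds than are shown below. What is called first, only, known or untested is meant among the compounds shown, and "the series" means these compounds.

Within the data shown here, in a functional assay on A549 cells (Homo sapiens) for cytotoxicity, read by MTT assay, with a stated time of 72 h (a higher number here means a weaker inhibitor, a lower number a stronger inhibitor), only two compounds have values so far. Compound 1 `CNC(=O)c1cc(Oc2ccc(C(=O)/C=C/c3ccc(Cl)c(Cl)c3)cc2)ccn1` gives 33700 nM, and compound 2 `CNC(=O)c1cc(Oc2ccc(C(=O)/C=C/c3ccc(F)cc3)cc2)ccn1` gives 18600 nM. Among the measured compounds shown here, these two values lie within the scatter of each other, so compound 2 stands level with the only other measured compound.

The next structure is compound 3 `CNC(=O)c1cc(Oc2ccc(C(=O)/C=C/c3ccc(OC)cc3)cc2)ccn1`, with methoxy in place of fluoro on an aromatic carbon, para to a large group: methoxy in place of fluoro on an aromatic carbon. The shared core stays the same.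

For the measured compounds named here, one measured step bears on this change. It is a 1.8-fold lower number from compound 1 to compound 2 (0.26 log units; within the scatter), which stays within the scatter although 3,4-dichlorophenyl gives way to 4-fluorophenyl. Going by the values given here, this is thin evidence, as no measured compound carries methoxy. On that single step, no change beyond the scatter is expected in this assay, and no direction is favoured with any confidence. The expected step is small: a 1.2-fold higher number from compound 2 to compound 3 (0.07 log units; within the scatter).

For compound 3 the estimate is 22000 nM, with an expected range from 10000 nM to 45000 nM.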

Compound 3, half-maximal inhibitory concentration: > 50000 nM
Compound 3: no number, only a limit (the forecaster's own chance of this, stated with the estimate: 5%); middle value at least 2.2-fold (0.35 log units) from the limit.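

In this assay compound 3 gives > 50000 nM, which is a limit of the assay and not a number, and it is the only reading of this kind among the compounds shown: the limit of > 50000 nM in this assay, at which 1 of the 3 values shown sits. Methoxy in place of fluoro on an aromatic carbon, para to a large group, gives an at least 2.6-fold higher number from compound 2 to compound 3 (0.42 log units; beyond the scatter) and is the first step in the series to pass beyond the scatter, so the group at this place can shift the reading in this assay, although only the floor of that shift is known. The comparison with the 3,4-dichlorophenyl compound is less informative, since an at least 1.4-fold higher number from compound 1 to compound 3 (0.17 log units; that floor lies within the scatter) gives only a floor, and that pair remains unseparated on the values shown.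

Going by these compounds, the true size of the methoxy step stays open, as does whether compound 3 can be separated from compound 1 once a number replaces the limit. Also open, on these data alone, is how an amine, a hydroxyl or a longer alkoxy chain at the same place would read against compound 2 and compound 3, and with only these three compounds no trend across groups at this position can be drawn.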